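The compounds below may be only part of what the source reports. "The series", "measured", "known", "first", "only" and "open" are said of these compounds alone.

Going by the values given here, in an assay on isolated protein for inhibition of Rho-associated protein kinase 2 (Homo sapiens), read by a luciferase reporter (on this read-out lower numbers stand for stronger inhibition and higher numbers for weaker inhibition), compound 1 `Cc1cccc(C2CNCC2C(=O)Nc2cc3cc[nH]c(=O)c3cc2Cl)c1` gives 5 nM and compound 2 `CC(C)c1cccc(C2CNCC2C(=O)Nc2cc3cc[nH]c(=O)c3cc2Cl)c1` gives 6 nM; the one step between them, a 1.2-fold higher number from compound 1 to compound 2 (0.08 log units; within the scatter), changes only a substituent on an aromatic carbon. Compound 3 `O=C(Nc1cc2cc[nH]c(=O)c2cc1Cl)[C@@H]1CCCNC1` gives 47 nM, the highest number of the three, beyond the scatter from both compound 2 and compound 1. Compound 4 `CN1CCC(C(=O)Nc2cc3cc[nH]c(=O)c3cc2Cl)CC1` differs from compound 3 by 1-methylpiperidin-4-yl in place of piperidin-3-yl on a carbonyl carbon. Among the compounds with values here, none of the measured steps touches this part of the molecule, so no step bears on it; the measured compounds show only that compound 3, which carries the piperidin-3-yl, stands above compound 1 and compound 2. The expected step is a 3.2-fold higher number from compound 3 to compound 4 (0.50 log units; beyond the scatter), a weakening, though with wide uncertainty. That puts the estimate for compound 4 at 150 nM, in a range from 40 nM to 600 nM.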

Compound 4, half-maximal inhibitory concentration: 31 nM
Compound 4: middle estimate off by 4.8-fold (0.68 log units), on the high side; the measured number lies below the stated range.
By their numbers in this assay, from the lowest: compounds 1 and 2 (each within the scatter of the next); then compounds 4 and 3 (each within the scatter of the next).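

In this assay the change on the carbonyl carbon gives a 1.5-fold lower number from compound 3 to compound 4 (0.18 log units; within the scatter), so this place accepts 1-methylpiperidin-4-yl as well as piperidin-3-yl, even though the entering group carries 0 hydrogen-bond donors against 1 and no defined stereocentre. Nothing available explains this result.

Since the ring attachment and the methyl differ together, the compounds shown do not separate their contributions. Going by these compounds, whether unsubstituted piperidin-4-yl, or a longer chain such as ethyl or a carboxylic acid on the ring nitrogen, would fit here remains open.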